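From ethyl to methoxycarbonyl on a shared core

This account rests on a few compounds, and the source may have more. Where it says the series, first, only, none or still open, it means among the compounds named here.

Measured in a functional assay on B16-F1 cells (Mus musculus) for cytotoxicity, read by sulforhodamine B assay, with a stated time of 48 h; a higher number here means a weaker inhibitor, a lower number a stronger inhibitor:
- Compound 1 `COc1cc(NC(=O)[C@@H]2CSC(c3ccccc3)N2)cc(OC)c1OC`: > 100000 nM, a limit of the assay
- Compound 2 `CCc1ccc(-c2nc(C(=O)c3cc(OC)c(OC)c(OC)c3)cs2)cc1`: 70 nM

Within the data shown here, compound 2, at 70 nM, holds the only actual number so far in this assay, so it cannot yet be ranked within a series. Compound 3 `COC(=O)c1ccc(-c2nc(C(=O)c3cc(OC)c(OC)c(OC)c3)cs2)cc1` keeps the core of compound 2 but carries methoxycarbonyl in place of ethyl on an aromatic carbon, para to a large group (methoxycarbonyl in place of ethyl on an aromatic carbon). Among the measured compounds shown here, no measured step gauges such a change. A moderate weakening in this assay is expected, with an estimated 2.9-fold higher number from compound 2 to compound 3 (0.46 log units; beyond the scatter). Compound 3 is expected at 200 nM, within an estimated range of 40 nM to 1500 nM.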

Compound 3, half-maximal inhibitory concentration: > 100000 nM
Compound 3: no number, only a limit; the forecaster's own chance of this, stated with the estimate: 5%; middle value at least 500-fold (2.69 log units) away from the limit.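

In this assay, the aromatic carbon para to a large group proves far from tolerant of every substituent: methoxycarbonyl in place of ethyl gives an at least 1400-fold higher number from compound 2 to compound 3 (3.15 log units; beyond the scatter). Compound 3 has only a limit of the assay and no number, so the step has a lower bound but no known size: the limit of > 100000 nM in this assay, at which 2 of the 3 values shown sit.

A single change at this position cannot show which feature of methoxycarbonyl matters. As far as these compounds go, whether a carboxylic acid, an amine or a longer alkyl chain here would retain the activity of compound 2 remains open.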